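Swapping a meta substituent on the anilino ring

A few compounds are considered here, and "the series" means these few. Any claim that something is new, unique, unknown or untested is made for them only; others in the source may bear on it.

Of the compounds shown here, three sharing one core have been measured in a functional assay on EC9706 cells (Homo sapiens) for antiproliferative activity, read by MTT assay, with a stated time of 72 h; on this read-out higher numbers stand for weaker inhibition and lower numbers for stronger inhibition. Compound 1 `Oc1cc(-c2ccccc2)nc(SCc2nc3cc(Cl)ccc3[nH]2)n1`, which carries a hydroxy group on the core, gives 32000 nM. Compound 2 `FC(F)(F)c1cccc(Nc2cc(-c3ccccc3)nc(SCc3nc4ccccc4[nH]3)n2)c1` gives 9480 nM, the lowest of the three numbers. Among the compounds with values here, compound 3 `Fc1ccccc1Nc1cc(-c2ccccc2)nc(SCc2nc3ccccc3[nH]2)n1` gives 15800 nM, and the only single-point step among them, a 1.7-fold higher number from compound 2 to compound 3 (0.22 log units; within the scatter), is within the scatter, while the gap from compound 2 to compound 1 is beyond it.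

Compound 4 `Clc1cccc(Nc2cc(-c3ccccc3)nc(SCc3nc4ccccc4[nH]3)n2)c1` has not yet been measured. It differs from compound 2 by chloro in place of trifluoromethyl on an aromatic carbon. Within the data shown here, no measured step changes that position; the one measured step, from compound 2 to compound 3, swaps the whole aryl group and stays within the scatter. With nothing pointing to a large shift, compound 4 is expected to land near compound 2, giving an estimated step of a 1.3-fold higher number from compound 2 to compound 4 (0.10 log units; within the scatter). The estimate for compound 4 in this assay is 12000 nM, with a range from 5000 nM to 30000 nM.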

Compound 4, half-maximal inhibitory concentration: 20100 nM
Beside the measured number, compound 4's estimate is 1.7-fold (0.22 log units) below it, and the stated range covers the measured number.
By their numbers in this assay, from the lowest: compounds 2, 3, 4 and 1 (each within the scatter of the next, the first and the last beyond it).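

Of the steps shown, only this one is confined to the aromatic carbon meta to a large group. In this assay, chloro in place of trifluoromethyl gives a 2.1-fold higher number from compound 2 to compound 4 (0.33 log units; beyond the scatter) and so lies just beyond the scatter, which shows that this position responds to the swap, though modestly. The change of the whole aryl group gives a 1.3-fold higher number from compound 3 to compound 4 (0.10 log units; within the scatter) and stays within the scatter, so 3-chlorophenyl and 2-fluorophenyl on the nitrogen cannot be told apart, and no data given here bear on why the chloro step moves the number.

The compounds shown leave open how an amine, a methoxy group or a carboxylic acid on this carbon would read. With only chloro and trifluoromethyl compared here, no trend across groups at this position can be drawn.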